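Inverting one stereocentre in a sphingosine kinase 1 inhibitor

The compounds below may be only part of what the source reports. "The series", "measured", "known", "first", "only" and "open" are said of these compounds alone.

Compound 1 `CCCCCCCc1nc(-c2ccc([C@@H](C)NC(=O)[C@H]3NCC[C@@H]3O)cc2)no1`: 3800 nM
Compound 2 `CCCCCCCc1noc(-c2ccc(CNC(=O)[C@H]3NCC[C@@H]3O)cc2)n1`: 61 nM
Compound 3 `CCCCCCCc1nc(-c2ccc(NC(=O)[C@H]3NCC[C@@H]3O)cc2)no1`: > 10000 nM

In an assay on isolated protein for inhibition of sphingosine kinase 1 (Homo sapiens) (a higher number here means a weaker inhibitor, a lower number a stronger inhibitor), compound 1 gives 3800 nM, the highest of the two numbers shown, while compound 2 gives 61 nM. For compound 3 the assay reports only a limit, > 10000 nM, and the limit of > 10000 nM in this assay, at which 1 of the 3 values shown sits, notes that one of the three values shown sits there. Compound 4 `CCCCCCCc1nc(-c2ccc([C@H](C)NC(=O)[C@H]3NCC[C@@H]3O)cc2)no1` is not yet measured. Compared with compound 1, (the two compounds have the same atoms and bonds and differ only in configuration as drawn: 1 of 3 stereo elements differ; a stereocentre at a saturated chain carbon is drawn R in compound 1 and S in compound 4). For the measured compounds named here, no measured pair here shows the effect of flipping this centre, so the direction of the step is open; an epimer at a chain carbon can shift potency either way or not beyond the scatter. Compound 4 is therefore expected to give about 500 nM in this assay, between 40 nM and 6000 nM, a step estimated as a 7.6-fold lower number from compound 1 to compound 4 (0.88 log units; beyond the scatter).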

Compound 4, half-maximal inhibitory concentration in the sphingosine kinase 1 assay: 48 nM
Compound 4: middle estimate off by 10-fold (1.02 log units), on the high side, within the range that was stated.
By their numbers in the sphingosine kinase 1 assay, from the lowest: compounds 4 and 2 (each within the scatter of the next); then compound 1. At a limit, above all of these: compound 3.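

Flipping one stereocentre at a saturated chain carbon is enough to change the result in the sphingosine kinase 1 assay sharply: compound 1 gives 3800 nM and compound 4 gives 48 nM, which is a 79-fold lower number from compound 1 to compound 4 (1.90 log units; beyond the scatter), with the S form the stronger inhibitor. In a physicochemical assay for solubility, at pH 7.4 (a higher number here means a more soluble compound, a lower number a less soluble compound), compound 1 gives 27 ug/mL and compound 4 gives 27 ug/mL, and the same flip gives no change at the digits printed from compound 1 to compound 4 (within the scatter), so this centre separates the two compounds in potency but not in solubility. The potency gap can be assigned to this centre alone, because nothing else separates the pair: the fact that compounds 1 and 4 differ only in the configuration as drawn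

The compounds shown leave open whether a larger group on this carbon, such as an ethyl group, would keep the potency of the S form.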